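Chloro step carried from a phenyl core to an anilino core

The source may report more compounds than this note shows. Statements on the series, on what has been measured and on what is new or still open speak of the compounds shown alone.

Measured in a functional assay on K562 cells (Homo sapiens) for antiproliferative activity, read by MTT assay, with a stated time of 72 h; on this read-out higher numbers stand for weaker inhibition and lower numbers for stronger inhibition:
compound 1 `COc1cc(C(=O)c2sc3ccccc3c2-c2ccccc2)cc(OC)c1OC` gives 2100 nM
compound 2 `COc1cc(C(=O)c2sc3ccccc3c2-c2ccc(Cl)cc2)cc(OC)c1OC` gives 4200 nM
compound 3 `COc1cc(C(=O)c2sc3ccccc3c2Nc2ccccc2)cc(OC)c1OC` gives 2300 nM

Compound 4 `COc1cc(C(=O)c2sc3ccccc3c2Nc2ccc(Cl)cc2)cc(OC)c1OC` has not been measured in this assay.

Compound 3 differs from compound 1 by anilino in place of phenyl on an aromatic carbon. The three measured numbers sit close together: a 1.1-fold higher number from compound 1 to compound 3 (0.04 log units; within the scatter), and a 1.8-fold lower number from compound 2 to compound 3 (0.26 log units; within the scatter).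

The change from compound 3 to compound 4 is chloro in place of hydrogen on an aromatic carbon. The same change, between compound 1 and compound 2, reads (chloro in place of hydrogen on an aromatic carbon); the place is described in identical words in both cases, and only the two cores differ, as told above. In this assay this earlier instance made a 2.0-fold higher number from compound 1 to compound 2 (0.30 log units; within the scatter).

The expectation for compound 4 rests on compound 3 at 2300 nM together with that one earlier step, which by itself stayed within the scatter. The expected step is a 2.0-fold higher number from compound 3 to compound 4 (0.30 log units; within the scatter), of the same kind and size as before, with no second instance to narrow it. Compound 4 is estimated at 4600 nM, with a range from 2000 nM to 10000 nM.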

Compound 4, half-maximal inhibitory concentration: 1100 nM
For compound 4 the middle estimate is 4.2-fold (0.62 log units) above the measured one; the whole stated range lies above it.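

In this assay, chloro in place of hydrogen does not carry over as one fixed step from the core of compound 1 to the core of compound 3: the same change on two cores in this assay, a 2.0-fold higher number (0.30 log units; within the scatter) from compound 1 to compound 2 and a 2.1-fold lower number (0.32 log units; beyond the scatter) from compound 3 to compound 4, 4.2-fold (0.62 log units) apart, beyond the scatter of two such steps On the core of compound 3 the change gives a 2.1-fold lower number from compound 3 to compound 4 (0.32 log units; beyond the scatter), while the two remaining comparisons read a 3.8-fold lower number from compound 2 to compound 4 (0.58 log units; beyond the scatter) and a 1.9-fold lower number from compound 1 to compound 4 (0.28 log units; within the scatter). This shows that a step read on one of these cores cannot simply be transferred to the other, but it rests on a single pair per core, with the earlier step itself within the scatter, and it gives no cause for the difference.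

As far as these compounds go, whether the split between the cores is particular to chloro stays open, and fluoro, methoxy or trifluoromethyl on the same aromatic carbon of both cores would test this. Also open, from the compounds shown here alone, is whether a methyl group in place of the amine hydrogen of compound 4 keeps the step seen with the anilino core.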